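A few compounds are considered here, and "the series" means these few. Any claim that something is new, unique, unknown or untested is made for them only; others in the source may bear on it.

Measured in a functional assay on HeLa cells (Homo sapiens) for inhibition, read by CCK-8 assay, with a stated time of 72 h, tested at 2 uM; a higher number here means more inhibition of growth at the concentration tested, a lower number less inhibition of growth:
- compound 1 `Cc1ccc(SCc2ccc(C(=O)Nc3ccccc3N)cc2)cc1`: 33.8%
- compound 2 `Nc1ccccc1NC(=O)c1ccc(CSc2ccc(Br)cc2)cc1`: 18.8%
- compound 3 `CC(C)(C)c1ccc(SCc2ccc(C(=O)Nc3ccccc3N)cc2)cc1`: 9.73%

Compound 2 holds the middle number of the three, but only one of its two gaps counts: a number 15 percentage points lower from compound 1 to compound 2 (beyond the scatter), while a number 9.1 percentage points lower from compound 2 to compound 3 (within the scatter).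

The next comparison is compound 4 `Cc1cc(C)cc(SCc2ccc(C(=O)Nc3ccccc3N)cc2)c1`, which has 3,5-dimethylphenyl in place of 4-bromophenyl on a sulfur.

The bearing steps are those away from the methyl-bearing compound 1, namely a number 15 percentage points lower from compound 1 to compound 2 (beyond the scatter) and a number 24.1 percentage points lower from compound 1 to compound 3 (beyond the scatter). Both are modest. Read in reverse, the first suggests that methyl in place of bromo could raise the number. For the measured compounds named here, no measured compound carries the 3,5-dimethylphenyl group, however, so this is only a weak guide, and the full return to compound 1 at 33.8% is not assumed.

A small upward move is expected for the new compound, estimated as a number 5.2 percentage points higher from compound 2 to compound 4 (within the scatter). For compound 4 the estimated value is 24%, with an expected range of 10% to 40%.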

Compound 4, percent growth inhibition at one concentration: 40.2%
The estimate for compound 4 lay 16.2 percentage points below the measured number, and the stated range ends below it.
By their numbers in this assay, from the lowest: compounds 3 and 2 (each within the scatter of the next); then compounds 1 and 4 (each within the scatter of the next).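

In this assay the step of a number 21.4 percentage points higher from compound 2 to compound 4 (beyond the scatter) shows that this group on the sulfur can carry two methyl groups and still stand clearly apart from 4-bromophenyl, so the position is not confined to a single substituent. Against 4-methylphenyl, the step of a number 6.4 percentage points higher from compound 1 to compound 4 (within the scatter) gives no readable gain or loss, which places compound 1 and compound 4 together as the upper pair and shows that the added methyl and the changed pattern make no measurable difference here. Nothing available explains why these two methyl-bearing phenyl groups read alike.

Still open, as far as these compounds go, is how a methoxy group, an amine or a carboxylic acid on this phenyl ring would read. Also open, from the compounds shown here alone, is whether a longer chain in place of the saturated chain carbon on the sulfur would keep the number of compound 4.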